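This account rests on a few compounds, and the source may have more. Where it says the series, first, only, none or still open, it means among the compounds named here.

Measured in a functional assay on HCT-116 cells (Homo sapiens) for antiproliferative activity, read by sulforhodamine B assay, with a stated time of 72 h; on this read-out lower numbers stand for stronger inhibition and higher numbers for weaker inhibition:
- compound 1 `Cn1ncc(Cl)c1-c1cc(C(=O)N[C@@H]2CN[C@H](CCN3CCC(O)CC3)C[C@H]2c2ccc(Cl)c(Cl)c2)oc1Cl`: 13700 nM
- compound 2 `Cn1ncc(Cl)c1-c1cc(C(=O)N[C@@H]2CN[C@H](CC(=O)O)C[C@H]2c2ccc(Cl)c(Cl)c2)oc1Cl`: 4020 nM

Of these two, compound 2 has the lower number, at 4020 nM. Among the measured compounds shown here, the only measured step, a 3.4-fold lower number from compound 1 to compound 2 (0.53 log units; beyond the scatter), came from putting carboxy in place of (4-hydroxypiperidin-1-yl)methyl on a saturated chain carbon bound to a saturated ring carbon.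

Compound 3 `CN(C)CC[C@@H]1C[C@@H](c2ccc(Cl)c(Cl)c2)[C@H](NC(=O)c2cc(-c3c(Cl)cnn3C)c(Cl)o2)CN1` is changed at that same place: (dimethylamino)methyl in place of carboxy on a saturated chain carbon bound to a saturated ring carbon. In words, (dimethylamino)methyl takes the place of carboxy. The entering group has no ring, so it is not the group of compound 1, yet it resembles that amine-bearing group far more than it resembles carboxy. The reverse of a 3.4-fold lower number from compound 1 to compound 2 (0.53 log units; beyond the scatter) is therefore the best available guide, and a modest move toward a higher number in this assay is expected, though a single step is thin evidence. The expected change is a 2.1-fold higher number from compound 2 to compound 3 (0.33 log units; beyond the scatter). For compound 3 the estimated value is 8500 nM, with an expected range from 2500 nM to 25000 nM.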

Compound 3, half-maximal inhibitory concentration: 1710 nM
Compound 3: the middle estimate sits 5.0-fold (0.70 log units) above what was measured; the measured number lies below the stated range.
By their numbers in this assay, from the lowest: compound 3; then compound 2; then compound 1.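

In this assay, (dimethylamino)methyl in place of carboxy gave a 2.4-fold lower number from compound 2 to compound 3 (0.37 log units; beyond the scatter), so a chain ending in an amine is not in itself a drawback at this place on a saturated chain carbon, as compound 1 alone might have suggested. Comparing the two amines, dimethylamino in place of 4-hydroxypiperidin-1-yl gave an 8.0-fold lower number from compound 1 to compound 3 (0.90 log units; beyond the scatter), the largest of the three steps, so the result depends on which amine is present and not simply on whether the chain ends in an amine or a carboxylic acid. Compound 2, with its carboxy group, falls between the two amine-bearing compounds, so no single trend from acid to amine covers all three. Nothing available here explains this order.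

As far as these compounds go, it remains open whether piperidin-1-yl, which lacks the hydroxy group of compound 1, would give a number closer to that of compound 1 or compound 3. From the compounds shown here alone, a primary amine at the same place, or a longer chain carrying the dimethylamino group, also remains open.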